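From 3-aminopropyl to 4-aminocyclohexyl

The compounds below may be only part of what the source reports. "The series", "measured", "known", "first", "only" and "open" are said of these compounds alone.

Results so far in a functional assay on SK-BR-3 cells (Homo sapiens) for cytotoxicity, read by MTT assay, with a stated time of 72 h; on this read-out higher numbers stand for weaker inhibition and lower numbers for stronger inhibition
- compound 1 `NCCCNc1c(C(=O)NCc2ccc(F)cc2)nc(Br)c2cccnc12` gives "not determined" (no result reported)
- compound 2 `CC(C)(C)OC(=O)N1CCN(c2c(C(=O)NCc3ccc(F)cc3)nc(Br)c3cccnc23)CC1` gives 3000 nM
- compound 3 `COc1cccc(CNC(=O)c2nc(Br)c3cccnc3c2N[C@H]2CC[C@H](N)CC2)c1` gives 6000 nM

Compound 1 has no single number here, so its place on the scale is open. The structure still to be measured is compound 4 `N[C@H]1CC[C@H](Nc2c(C(=O)NCc3ccc(F)cc3)nc(Br)c3cccnc23)CC1` and the change is 4-aminocyclohexyl in place of 3-aminopropyl on a nitrogen on an aromatic ring which puts 4-aminocyclohexyl in place of 3-aminopropyl on a nitrogen on an aromatic ring. For the measured compounds named here, no step from compound 1 can be sized directly. The nearest guide is compound 3, which carries the same 4-aminocyclohexyl group but differs elsewhere and gives 6000 nM in this assay while compound 2 gives 3000 nM in the same test. Compound 4 is therefore expected at 5000 nM within an estimated range of 1800 nM to 14000 nM on this reasoning.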

Compound 4, half-maximal inhibitory concentration: 2000 nM
For compound 4 the middle estimate is 2.5-fold (0.40 log units) above the measured one; measured number inside the range.
By their numbers in this assay, from the lowest: compounds 4, 2 and 3 (each within the scatter of the next, the first and the last beyond it).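

For the compounds shown here, with 4-aminocyclohexyl held fixed, this assay gives the first comparison that differs in one place: 4-fluorophenyl in place of 3-methoxyphenyl brings a 3.0-fold lower number from compound 3 to compound 4 (0.48 log units; beyond the scatter). The step from compound 1 cannot be read, so the effect of 4-aminocyclohexyl in place of 3-aminopropyl remains unsized. No measurement here explains the difference between compound 3 and compound 4.

The compounds shown leave open how 4-hydroxycyclohexyl, with a hydroxyl in place of the amine, would compare with compound 4. They also leave open how an unsubstituted phenyl would compare with 4-fluorophenyl.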